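This account rests on a few compounds, and the source may have more. Where it says the series, first, only, none or still open, it means among the compounds named here.

Compound 1 `O=C(CC1CCCCC1)N1CCN(c2nc(=O)c3cc(C(F)(F)F)cc([N+](=O)[O-])c3s2)CC1` gives 0.12 ug/mL in a physicochemical assay for solubility, read by HPLC; a lower number here means a less soluble compound, a higher number a more soluble compound. Compound 2 `O=C(c1ccccc1F)N1CCN(c2nc(=O)c3cc(C(F)(F)F)cc([N+](=O)[O-])c3s2)CC1` gives 3.1 ug/mL in this assay, and compound 3 `O=c1nc(N2CCN(CC3CCCCC3)CC2)sc2c([N+](=O)[O-])cc(C(F)(F)F)cc12` gives 9.07 ug/mL, the highest of the three numbers, ahead of compound 2 by a 2.9-fold higher number from compound 2 to compound 3 (0.47 log units; beyond the scatter) and far ahead of compound 1 by a 76-fold higher number from compound 1 to compound 3 (1.88 log units; beyond the scatter). Compound 4 `O=C(c1ccccc1Cl)N1CCN(c2nc(=O)c3cc(C(F)(F)F)cc([N+](=O)[O-])c3s2)CC1` is not yet measured. The change from compound 3 to compound 4 is (2-chlorophenyl)carbonyl in place of cyclohexylmethyl on an amine nitrogen in a ring. The step that bears on it is a 2.9-fold higher number from compound 2 to compound 3 (0.47 log units; beyond the scatter), where a carbonyl-linked group on the ring nitrogen went with a modestly lower number than cyclohexylmethyl; a 76-fold higher number from compound 1 to compound 3 (1.88 log units; beyond the scatter) concerned a different entering group and was much larger. A modest downward step is therefore expected. Compound 4 is expected to give 2.5 ug/mL, ranging from 0.8 ug/mL to 7 ug/mL. The expected step is a 3.6-fold lower number from compound 3 to compound 4 (0.56 log units; beyond the scatter).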

Compound 4, solubility: 8.18 ug/mL
Compound 4: middle estimate off by 3.3-fold (0.51 log units), on the low side, and the stated range ends below it.
By their numbers in this assay, from the lowest: compound 1; then compound 2; then compounds 4 and 3 (each within the scatter of the next).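

On the amine nitrogen in a ring, (2-chlorophenyl)carbonyl and cyclohexylmethyl cannot be told apart in this assay with a 1.1-fold lower number from compound 3 to compound 4 (0.04 log units; within the scatter) here, so a carbonyl-linked group at this position does not by itself go with a lower number. The halogen alone moves the number: chloro in place of fluoro on an aromatic carbon gives a 2.6-fold higher number from compound 2 to compound 4 (0.42 log units; beyond the scatter) and stands beyond the scatter, while a carbonyl that carries 2-chlorophenyl rather than cyclohexylmethyl gives a 68-fold higher number from compound 1 to compound 4 (1.83 log units; beyond the scatter) as the large step. Nothing measured here accounts for these steps. The compounds shown leave open whether bromo or methyl in place of chloro would follow the same direction, and how an amine on the phenyl ring would read.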